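This account rests on a few compounds, and the source may have more. Where it says the series, first, only, none or still open, it means among the compounds named here.

Measured compounds:
compound 1 `C=CC(=O)Nc1cc(Oc2ccc(NC(=O)Nc3ccc(C)c(C(F)(F)F)c3)cc2)ncn1`, 1940 nM
compound 2 `Cc1ccc(NC(=O)Nc2ccc(Oc3cc(N4CCN[C@H](C)C4)ncn3)cc2)cc1C(F)(F)F`, 8920 nM
compound 3 `Cc1ccc(NC(=O)Nc2ccc(Oc3cc(NCCO)ncn3)cc2)cc1C(F)(F)F`, > 10000 nM

From the compounds shown here alone, in a functional assay on BaF3 cells (Mus musculus) for inhibition, read by CCK-8 assay, with a stated time of 72 h (a lower number here means a stronger inhibitor of growth, a higher number a weaker inhibitor of growth), compound 3 gives only a limit, > 10000 nM, so its true number is unknown and it sits at the limit of > 10000 nM in this assay, at which 1 of the 3 values shown sits. Compound 1 and compound 2 give numbers, and compound 2 is weaker than compound 1 by a 4.6-fold higher number from compound 1 to compound 2 (0.66 log units; beyond the scatter).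

Compound 4 is `CCC(=O)Nc1cc(Oc2ccc(NC(=O)Nc3ccc(C)c(C(F)(F)F)c3)cc2)ncn1`. It differs from compound 3 by propanoyl in place of 2-hydroxyethyl on a nitrogen on an aromatic ring. For the measured compounds named here, the measured step that bears on this change is the one from compound 1, which carries vinylcarbonyl on that nitrogen, to compound 3: an at least 5.1-fold higher number from compound 1 to compound 3 (0.71 log units; beyond the scatter). Compound 4 returns a carbonyl-bearing group to that nitrogen, propanoyl rather than vinylcarbonyl, so the step from compound 3 to compound 4 is expected to run in the opposite direction, toward a lower number in this assay, and to be at least modest in size. Since compound 3 stands only at a limit, the step can only be bounded from below. The estimate is an at least 2.2-fold lower number from compound 3 to compound 4 (0.34 log units; beyond the scatter). Compound 4 is therefore expected to give about 4500 nM in this assay, between 1500 nM and 15000 nM.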

Compound 4, concentration for 50% growth inhibition: 990 nM
The estimate for compound 4 lay 4.5-fold (0.66 log units) above the measured number; the whole stated range lies above it.
By their numbers in this assay, from the lowest: compounds 4 and 1 (each within the scatter of the next); then compound 2. At a limit, above all of these: compound 3.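

In this assay, the double bond of compound 1 proves dispensable at this position: the saturated propanoyl group serves as well as vinylcarbonyl on that nitrogen, with a 2.0-fold lower number from compound 1 to compound 4 (0.29 log units; within the scatter), so ethyl and vinyl on the carbonyl carbon cannot be told apart here. The earlier compounds shown here could not separate the carbonyl-bearing nitrogen from its double bond, whereas compound 4 shows that propanoylamino alone stands clear of the groups without a carbonyl, with a 9.0-fold lower number from compound 2 to compound 4 (0.95 log units; beyond the scatter) and an at least 10-fold lower number from compound 3 to compound 4 (1.00 log units; beyond the scatter). From the compounds shown here alone, compound 3 gives only a limit, so the second of those steps is a floor and its true size is unknown: the limit of > 10000 nM in this assay, at which 1 of the 4 values shown sits.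

Going by these compounds, whether a shorter acetyl group, a longer butanoyl chain or a branched acyl group on that nitrogen would keep the number of compound 4 remains open. Also open is whether a sulfonyl group or a urea in place of the carbonyl would do the same, and the compounds shown give no reason why the two acylamino compounds stand apart from the two with amines.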